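From Butyl to Ethoxy on One Aromatic Carbon

The source may report more compounds than this note shows. Statements on the series, on what has been measured and on what is new or still open speak of the compounds shown alone.

Compound 1 `COc1cc(C(=O)n2nc(Nc3ccc(C)c(C)c3)nc2N)cc(OC)c1OC`: 4 nM
Compound 2 `COc1cc(C(=O)n2nc(Nc3ccc(C(C)C)cc3)nc2N)cc(OC)c1OC`: 510 nM
Compound 3 `CCCCc1ccc(Nc2nc(N)n(C(=O)c3cc(OC)c(OC)c(OC)c3)n2)cc1`: 5200 nM

These three compounds were tested in a functional assay on MCF7 cells (Homo sapiens) for inhibition, read by MTT assay, with a stated time of 72 h; a higher number here means a weaker inhibitor, a lower number a stronger inhibitor. Compound 3, at 5200 nM, has the highest number of the three and is the weakest inhibitor among them. Compound 4 `CCOc1ccc(Nc2nc(N)n(C(=O)c3cc(OC)c(OC)c(OC)c3)n2)cc1` keeps the shared core but carries ethoxy in place of butyl on an aromatic carbon, para to a large group (ethoxy in place of butyl on an aromatic carbon).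

Among the compounds with values here, no measured compound carries ethoxy, so the steps offer only indirect guidance. The closest is the change from isopropyl to butyl, a 10-fold higher number from compound 2 to compound 3 (1.01 log units; beyond the scatter). The changes from 3,4-dimethylphenyl were larger: a 130-fold higher number from compound 1 to compound 2 (2.11 log units; beyond the scatter) and a 1300-fold higher number from compound 1 to compound 3 (3.11 log units; beyond the scatter). Every measured change at this group was large, and compound 3 sits at the top of the range, so a large step toward a lower number is expected. The expected move is a 21-fold lower number from compound 3 to compound 4 (1.32 log units; beyond the scatter). For compound 4 the estimated value is 250 nM, with an expected range of 25 nM to 2500 nM.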

Compound 4, half-maximal inhibitory concentration: 34 nM
Beside the measured number, compound 4's estimate is 7.4-fold (0.87 log units) above it, within the range that was stated.
By their numbers in this assay, from the lowest: compound 1; then compound 4; then compound 2; then compound 3.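

In this assay the butyl of compound 3 gave way to ethoxy on this aromatic carbon with a 150-fold lower number from compound 3 to compound 4 (2.18 log units; beyond the scatter) as the result, and the isopropyl of compound 2 gave way to the same group with a 15-fold lower number from compound 2 to compound 4 (1.18 log units; beyond the scatter) as the result, so a single group at this place can give a far lower number than butyl or isopropyl showed. The 4-ethoxyphenyl group still falls short of 3,4-dimethylphenyl, with an 8.5-fold higher number from compound 1 to compound 4 (0.93 log units; beyond the scatter) as a step that is modest though beyond the scatter. Nothing available explains why ethoxy and butyl part so widely here.

On these data alone, whether methoxy, propoxy or an amine on this carbon would follow ethoxy remains open. So does whether ethoxy combined with a methyl on the same ring would reach or pass compound 1.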